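The source may hold more compounds than are shown below. What is called first, only, known or untested is meant among the compounds shown, and "the series" means these compounds.

Measured in an ADME assay for metabolic stability, read by HPLC, in simulated gastric fluid, with a stated time of 12 h, at pH 1.2; a lower number here means that the compound disappears faster, a higher number that the compound lasts longer:
- Compound 1 `O=C(O)[C@@H](CO)NC(=O)[C@H]1C[C@H](O)CN1`: > 12 h (a limit)
- Compound 2 `O=C(O)[C@H](CO)NC(=O)[C@H]1C[C@@H](O)CN1`: > 12 h (a limit)
- Compound 3 `O=C(O)[C@H](CO)NC(=O)[C@@H]1C[C@H](O)CN1`: > 12 h (a limit)

Compound 3 stands only at a limit, > 12 h, and not at a number. Compound 4 `O=C(O)[C@H](CO)NC(=O)[C@@H]1C[C@@H](O)CN1` keeps the atoms and bonds of compound 3: the two compounds have the same atoms and bonds and differ only in configuration as drawn: 1 of 3 stereo elements differ; a stereocentre at a saturated ring carbon is drawn S in compound 3 and R in compound 4. The measured steps that bear on this are also changes of configuration: a step that the two limits leave unreadable from compound 1 to compound 3, a step that the two limits leave unreadable from compound 2 to compound 3 and a step that the two limits leave unreadable from compound 1 to compound 2. None has a readable size, so none measures what such a change does. What they share is the limit of > 12 h in this assay, at which 3 of the 3 values shown sit. No direction can be assigned in this assay, and the expected step that the limit leaves unreadable from compound 3 to compound 4 is none beyond the scatter. Compound 4 is expected at 24 h, with an estimated range from 12 h to 48 h.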

Compound 4, half-life: > 12 h
Compound 4: only a limit was reported (the forecaster's own chance of this, stated with the estimate: 90%); the middle value is on the limit's open side.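

In this assay, among these compounds, compound 4 gives > 12 h, a limit, so no step to compound 4 from compound 1, compound 2 or compound 3 can be read. The compounds shown leave open whether configuration affects the half-life in this assay at all.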